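Triazole nitrogen substituent: allyl to phenyl

This account rests on a few compounds, and the source may have more. Where it says the series, first, only, none or still open, it means among the compounds named here.

Measured so far in a functional assay on HepG2 cells (Homo sapiens) for inhibition; on this read-out lower numbers stand for stronger inhibition and higher numbers for weaker inhibition:
compound 1 `CCn1c(SCC(=O)Nc2ccc(C(=O)O)cc2)nnc1-c1ccncc1`: 41000 nM
compound 2 `C=CCn1c(SCC(=O)Nc2ccc(C(=O)O)cc2)nnc1-c1ccncc1`: 4720 nM
compound 3 `CONC(=O)c1ccccc1Nc1nc(Nc2cc(C)nn2C(C)C)ncc1Cl`: 3240 nM

Compound 2 stands second highest of the three numbers in this assay. Compound 3, built on a different core, lies within the scatter of compound 2, so no order between the two is claimed. Going by the values given here, compound 1 shares the core of compound 2, and the one measured step within that core, an 8.7-fold lower number from compound 1 to compound 2 (0.94 log units; beyond the scatter), arises from a vinyl in place of methyl on a saturated chain carbon bound to an aromatic nitrogen and is beyond the scatter.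

Compound 4 `O=C(CSc1nnc(-c2ccncc2)n1-c1ccccc1)Nc1ccc(C(=O)O)cc1` differs from compound 2 by phenyl in place of allyl on an aromatic nitrogen. Among the compounds with values here, no measured pair covers a ring in place of a chain on this nitrogen. Within the data shown here, the step from compound 1 to compound 2 shows only that a change at this position can move the number by a modest amount; the direction for a phenyl is not fixed by any measured pair. The expectation is therefore a step of modest size at most in this assay, with a wide range, and the expected step is a 1.6-fold lower number from compound 2 to compound 4 (0.20 log units; within the scatter). Compound 4 is estimated at 3000 nM, expected to fall between 800 nM and 12000 nM.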

Compound 4, half-maximal inhibitory concentration: 3780 nM
For compound 4 the middle estimate is 1.3-fold (0.10 log units) below the measured one, and the stated range covers the measured number.
By their numbers in this assay, from the lowest: compounds 3, 4 and 2 (each within the scatter of the next); then compound 1.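

In this assay the aromatic nitrogen of the shared core now carries a ring as well as chains, and a 1.2-fold lower number from compound 2 to compound 4 (0.10 log units; within the scatter) leaves phenyl and allyl inseparable, so replacing the chain with one six-membered aromatic ring of carbon only gives no readable change from allyl. Set against the ethyl of compound 1, phenyl gives an 11-fold lower number from compound 1 to compound 4 (1.04 log units; beyond the scatter) and allyl gives an 8.7-fold lower number from compound 1 to compound 2 (0.94 log units; beyond the scatter); among these three compounds the ethyl compound therefore stands alone with the highest number, while the two groups with a double bond or an aromatic ring sit together. No available data give a cause for this separation of ethyl from allyl and phenyl.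

As far as these compounds go, it remains open whether propyl, a longer chain, or a saturated ring such as cyclohexyl would group with ethyl or with allyl and phenyl. Also open, from the compounds shown here alone, is how far the phenyl itself tolerates substitution, for example with a methoxy group, an amine or a carboxylic acid, and whether the number stays in the range of compound 4 3780 nM when it does.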